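Same Atoms, Joined Differently: From Compound 3 to Compound 4

A few compounds are considered here, and "the series" means these few. Any claim that something is new, unique, unknown or untested is made for them only; others in the source may bear on it.

Three related compounds have been measured in an ADME assay on HEK293 cells (Homo sapiens) for cytotoxicity, read by MTT assay, with a stated time of 48 h; on this read-out higher numbers stand for weaker inhibition and lower numbers for stronger inhibition. Compound 1 `O=C1/C(=C\c2ccccc2)S/C(=N/c2ccccc2)N1Cc1ccncc1` gives 64700 nM, compound 2 `Cc1ccc(/C=C2/S/C(=N/c3ccccc3)N(Cc3ccncc3)C2=O)cc1` gives 49500 nM, and compound 3 `COc1ccc(/C=C2/S/C(=N/c3ccccc3)N(Cc3ccncc3)C2=O)cc1OC` gives 171000 nM. That last number is the highest of the three, so compound 3 shows the weakest inhibition so far.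

Compound 4 `CCOc1cc(/C=C2/S/C(=N/c3ccccc3)N(Cc3ccncc3)C2=O)ccc1O` has not yet been measured. It differs from compound 3 in one group, on a double-bonded chain carbon bound to a double-bonded ring carbon: 3-ethoxy-4-hydroxyphenyl in place of 3,4-dimethoxyphenyl on a double-bonded chain carbon bound to a double-bonded ring carbon.

Two measured steps changed the group at this same place. One is a 2.6-fold higher number from compound 1 to compound 3 (0.42 log units; beyond the scatter), and the other is a 3.5-fold higher number from compound 2 to compound 3 (0.54 log units; beyond the scatter). Both are modest, and both end at the 3,4-dimethoxyphenyl group that now leaves. A smaller change on the same aromatic ring, a 1.3-fold lower number from compound 1 to compound 2 (0.12 log units; within the scatter), stayed within the scatter. For the measured compounds named here, no measured compound carries the 3-ethoxy-4-hydroxyphenyl group, so these steps give only a rough guide. A drop no larger than those modest steps seems likely, and it may well stay within the scatter.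

The expected change is a 1.7-fold lower number from compound 3 to compound 4 (0.23 log units; within the scatter). For compound 4 the estimated value is 100000 nM, with an expected range from 40000 nM to 230000 nM.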

Compound 4, half-maximal inhibitory concentration: 46500 nM
Compound 4: middle estimate off by 2.2-fold (0.33 log units), on the high side, within the range that was stated.
By their numbers in this assay, from the lowest: compounds 4, 2 and 1 (each within the scatter of the next); then compound 3.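

In this assay, the same atoms joined differently give a 3.7-fold lower number from compound 3 to compound 4 (0.57 log units; beyond the scatter), so at this place the arrangement of the atoms matters, not just which atoms are present. The new group also returns to the level of the simpler groups, with a 1.1-fold lower number from compound 2 to compound 4 (0.03 log units; within the scatter) and a 1.4-fold lower number from compound 1 to compound 4 (0.14 log units; within the scatter), both within the scatter; among these four compounds, only the 3,4-dimethoxyphenyl group of compound 3 stands apart. No measurement shown here explains this difference, including whether it is tied to the single hydrogen-bond donor counted on the entering group.

The swap alters two things at once, turning one methoxy into a hydroxy and the other into an ethoxy, so the compounds shown cannot say which of these goes with the step; a ring carrying hydroxy and methoxy together, or ethoxy and methoxy together, would separate them. From the compounds shown here alone, it also remains open whether a quite different group at this place, such as an amine or a carboxylic acid on the aromatic ring, would move the number away from the level shared by compound 1, compound 2 and compound 4.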